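Moving the nitro group: compound 3 to compound 4

This account rests on a few compounds, and the source may have more. Where it says the series, first, only, none or still open, it means among the compounds named here.

Measured so far in a functional assay on the whole organism (strain albino) with Rattus norvegicus as the target, read by paw edema, with stated times of 1 h and 4 h, at a dose of 25 mg/kg by the oral route; a lower number here means a weaker effect, a higher number a stronger effect of the compound at the dose given:
compound 1 `COc1ccc(/C=C/C(=O)c2ccc(NC(=O)c3cc(Cl)ccc3OC)cc2)cc1` gives 79%
compound 2 `COc1ccc(C2CC(c3ccc(NC(=O)c4cc(Cl)ccc4OC)cc3)=NN2C)cc1` gives 88.1%
compound 3 `COc1ccc(Cl)cc1C(=O)Nc1ccc(C2=NN(C)C(c3ccccc3[N+](=O)[O-])C2)cc1` gives 96.5%

Compound 3 has the highest of the three numbers. Its nearest neighbour is compound 2, whose number lies within the scatter of that of compound 3, so the two cannot be ranked against each other; compound 1 stands further off, beyond the scatter. Compound 4 `COc1ccc(Cl)cc1C(=O)Nc1ccc(C2=NN(C)C(c3ccc([N+](=O)[O-])cc3)C2)cc1` differs from compound 3 only in one group on a saturated ring carbon: 4-nitrophenyl in place of 2-nitrophenyl on a saturated ring carbon. The two compounds hold the same atoms, joined differently.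

Going by the values given here, only one measured step touches this part of the molecule: a number 8.4 percentage points higher from compound 2 to compound 3 (within the scatter). That step exchanged a 4-methoxyphenyl for a 2-nitrophenyl and moved the number by less than the scatter, so a swap of groups at this position has so far made no difference that can be trusted. Among the compounds with values here, no measured step compares a 2-nitrophenyl with a 4-nitrophenyl, so nothing here speaks for a large shift in either direction. Compound 4 is therefore expected to land close to compound 3, with the step of a number 5.5 percentage points lower from compound 3 to compound 4 (within the scatter) estimated to stay within the scatter. The estimate for compound 4 in this assay is 91%, expected to fall between 79% and 100%.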

Compound 4, a percentage reported as activity, at one dose (the size of the read-out at that dose, not a potency): 93%
Estimate against measurement, compound 4: 2 percentage points below; measured number inside the range.
By their numbers in this assay, from the lowest: compounds 1, 2, 4 and 3 (each within the scatter of the next, the first and the last beyond it).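

In this assay, shifting the nitro group around the same phenyl ring, with 4-nitrophenyl in place of 2-nitrophenyl on the saturated ring carbon, gives a number 3.5 percentage points lower from compound 3 to compound 4 (within the scatter), so the two placements of the nitro group cannot be told apart in this read-out. The comparison with the methoxy analogue, nitro in place of methoxy on an aromatic carbon, gives a number 4.9 percentage points higher from compound 2 to compound 4 (within the scatter), which adds a second exchange of this kind and means that 4-methoxyphenyl, 2-nitrophenyl and 4-nitrophenyl at this carbon all read alike within the scatter, so the position has so far tolerated each of these groups without a difference that can be trusted. Nothing available explains why these three groups give such similar readings.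

Still open, from the compounds shown here alone, is whether a 3-nitrophenyl, or a phenyl ring carrying an amine or a carboxylic acid in place of the nitro group, would separate from these compounds on the same shared core. Going by these compounds, each number also comes from a single dose, so whether compound 2, compound 3 and compound 4 would differ in the size of their effect at any other dose remains unknown.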